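Amide side chain variation on the shared core

The source may report more compounds than this note shows. Statements on the series, on what has been measured and on what is new or still open speak of the compounds shown alone.

Measured so far in an assay on isolated protein for binding affinity to B1 bradykinin receptor (Homo sapiens); on this read-out lower numbers stand for stronger inhibition and higher numbers for weaker inhibition:
compound 1, `Cc1cc(C)c2cccc(OCc3c(Cl)ccc(S(=O)(=O)NC4(C(=O)N5CCN(C(=O)[C@@H](N)CCCCN)CC5)CCCC4)c3Cl)c2n1`: < 10000 nM (a limit)
compound 2, `Cc1cc(C)c2cccc(OCc3c(Cl)ccc(S(=O)(=O)NC4(C(=O)N5CCN(C(=O)CCCCC[N+](C)(C)C)CC5)CCCC4)c3Cl)c2n1`: < 10000 nM (a limit)
compound 3, `Cc1cc(C)c2cccc(OCc3c(Cl)ccc(S(=O)(=O)NC4(C(=O)N5CCN(C(=O)C[C@@H](N)CCC[N+](C)(C)C)CC5)CCCC4)c3Cl)c2n1`: < 10000 nM (a limit)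

Compound 3 gives only a limit in this assay, not a number. For the measured compounds named here, the same holds for the other two values shown: the limit of < 10000 nM in this assay, at which 3 of the 3 values shown sit, so no compound in the set has a placed value and none can be ranked against another.

The step under consideration leads to compound 4, `Cc1cc(C)c2cccc(OCc3c(Cl)ccc(S(=O)(=O)NC4(C(=O)N5CCN(C(=O)[C@@H](N)CC[N+](C)(C)C)CC5)CCCC4)c3Cl)c2n1`. The change is a group of 8 heavy atoms (6 carbon, 2 nitrogen; no ring) in place of a group of 10 heavy atoms (8 carbon, 2 nitrogen; no ring), on a carbonyl carbon; the group that enters keeps the defined stereocentre, the single donor and acceptor and the net charge, and is shorter by the count given.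

Going by the values given here, three measured steps touch the same carbonyl: a step that the two limits leave unreadable from compound 1 to compound 2, a step that the two limits leave unreadable from compound 1 to compound 3 and a step that the two limits leave unreadable from compound 2 to compound 3. None of them is readable in size or direction, since both ends sit at the limit. The data therefore give no readable step for a change at this position, and no direction can be expected for a step that the limit leaves unreadable from compound 3 to compound 4 beyond what the limit allows.

Compound 4 is accordingly expected to sit near the other three, with the estimate 300 nM in a range from 10 nM to 8000 nM, and a high chance that this assay again reports only a limit.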

Compound 4, inhibition constant: < 10000 nM
Compound 4 ended at the assay's limit (the forecaster's own chance of this, stated with the estimate: 70%); the middle value does not contradict the limit.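

No new step can be read between compound 4 and compound 1, compound 2 or compound 3 in this assay, since every one of these compounds gives only a limit: the limit of < 10000 nM in this assay, at which 4 of the 4 values shown sit.

The compounds shown leave open how strongly each binds, and whether changing the group on the carbonyl carbon alters the read-out in this assay at all.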